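Swapping trifluoromethyl for hydroxy in compound 4

The source may report more compounds than this note shows. Statements on the series, on what has been measured and on what is new or still open speak of the compounds shown alone.

compound 1 `CN(C)C(=O)c1cc2cnc(Nc3ccc(NC(=O)C4(C(=O)Nc5cccc(F)c5)CC4)cc3)nc2n1C1CCCC1` gives 33.2%
compound 2 `COc1cccc(NC(=O)C2(C(=O)Nc3ccc(Nc4ncc5cc(C(=O)N(C)C)n(C6CCCC6)c5n4)cc3)CC2)c1` gives 77.2%
compound 3 `CN(C)C(=O)c1cc2cnc(Nc3ccc(NC(=O)C4(C(=O)Nc5ccc(C(F)(F)F)cc5)CC4)cc3)nc2n1C1CCCC1` gives -25.3%

In a functional assay on A549 cells (Homo sapiens) for inhibition, read by CCK-8 assay, with a stated time of 72 h, tested at 1 uM (on this read-out higher numbers stand for more inhibition of growth at the one concentration tested and lower numbers for less inhibition of growth), compound 3 stands lowest of the three, at -25.3%, clearly apart from both others. Compound 4 `CN(C)C(=O)c1cc2cnc(Nc3ccc(NC(=O)C4(C(=O)Nc5ccc(O)cc5)CC4)cc3)nc2n1C1CCCC1` differs from it in one group: hydroxy in place of trifluoromethyl on an aromatic carbon. Among the measured compounds shown here, this is hydroxy in place of trifluoromethyl on an aromatic carbon, and no measured pair shows this exact swap. The nearest evidence is the two large steps that bring in the 4-(trifluoromethyl)phenyl group, a number 58.5 percentage points lower from compound 1 to compound 3 (beyond the scatter) and a number 102.5 percentage points lower from compound 2 to compound 3 (beyond the scatter). The step of a number 44 percentage points higher from compound 1 to compound 2 (beyond the scatter) shows that a swap on this same ring can also move the number far, so the hydroxy group could land high or low. Only compound 3 carries trifluoromethyl, which makes this thin evidence. Still, the two compounds without that group both sit far higher, so a large rise is expected, a number 70.3 percentage points higher from compound 3 to compound 4 (beyond the scatter). Compound 4 is estimated at 45%, with an expected range from 5% to 85%.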

Compound 4, percent growth inhibition at one concentration: 93.6%
For compound 4 the middle estimate is 48.6 percentage points below the measured one; measured number outside the range, above it.
By their numbers in this assay, from the lowest: compound 3; then compound 1; then compound 2; then compound 4.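

In this assay, putting hydroxy in place of trifluoromethyl on an aromatic carbon para to a large group gives a number 118.9 percentage points higher from compound 3 to compound 4 (beyond the scatter) and so takes this one position from the bottom of the series to the top. Among the compounds shown here, the 4-hydroxyphenyl group also outdoes the two rings of the earlier compounds, with a number 16.4 percentage points higher from compound 2 to compound 4 (beyond the scatter) and a number 60.4 percentage points higher from compound 1 to compound 4 (beyond the scatter) and this makes compound 4 the most active of the four, which the earlier compounds, with compound 2 on top, gave no sign of. For the compounds shown here, nothing given here explains why this swap moves the number so far.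

As far as these compounds go, what an amine or a carboxylic acid would give at this same position remains open. So does whether hydroxy would hold its number on the ring position that carries fluoro in compound 1 and methoxy in compound 2.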